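From Compound 1 to Compound 3: an Added Aromatic Substituent

A few compounds are considered here, and "the series" means these few. Any claim that something is new, unique, unknown or untested is made for them only; others in the source may bear on it.

Compound 1 `COc1ccc([C@H]2CC(=O)N(c3ccccc3)C2)cc1OC1CCCC1` stands at the edge of what a functional assay on HEK293 cells (Homo sapiens) for cytotoxicity (on this read-out lower numbers stand for higher toxicity in this test and higher numbers for lower toxicity in this test), can report: compound 1 gives > 10000 nM, which is a limit of the assay rather than a number. Compound 2 `COc1ccc([C@H]2CC(=O)N(c3ccccn3)C2)cc1OC1CCCC1` gives > 10000 nM, again a limit. The step that the two limits leave unreadable from compound 1 to compound 2 is therefore unreadable. Compound 3 `COc1ccc([C@H]2CC(=O)N(c3cccc([S+](C)[O-])c3)C2)cc1OC1CCCC1` differs from compound 1 by a group of 3 heavy atoms (1 carbon, 1 oxygen, 1 sulfur; no ring) in place of a hydrogen atom, on an aromatic carbon. Going by the values given here, no measured step bears on this change, and both values shown sit at the limit of > 10000 nM in this assay, at which 2 of the 2 values shown sit, so no direction can be drawn from them. Compound 3 is expected to stay near that limit, a step of a number no higher from compound 1 to compound 3 (the limit leaves the size open). The estimate for compound 3 is 10000 nM, with a range from 5000 nM to 30000 nM.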

Compound 3, half-maximal cytotoxic concentration: > 10000 nM
Compound 3: no number, only a limit; the forecaster's own chance of this, stated with the estimate: 80%; the middle value sits exactly at the limit.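

Going by these compounds alone, compound 1, compound 2 and compound 3 all give a limit rather than a number in this assay, so no step among them can be read: the limit of > 10000 nM in this assay, at which 3 of the 3 values shown sit. The compounds shown leave open whether the group added in compound 3 changes this read-out at all.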